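The source may report more compounds than this note shows. Statements on the series, on what has been measured and on what is new or still open speak of the compounds shown alone.

Of the compounds shown here, three that share one core have been tested in a functional assay on HeLa cells (Homo sapiens) for cytotoxicity, read by MTT assay, with a stated time of 72 h, tested at 1 uM; on this read-out lower numbers stand for less inhibition of growth and higher numbers for more inhibition of growth at the one concentration tested. Compound 1 `Cc1cccc(/C(N)=N/NC(=S)N2CCN(c3ccccn3)CC2)n1` gives 51.8%, compound 2 `N/C(=N\NC(=S)N1CCOCC1)c1ccccn1` gives 12.7%, and compound 3 `Cc1ccnc(/C(N)=N/NC(=S)N2CCOCC2)c1` gives 39.1%. Compound 2 therefore stands lowest of the three numbers. For the measured compounds named here, the only step between close neighbours is a number 26.4 percentage points higher from compound 2 to compound 3 (beyond the scatter), which concerns a methyl group and not the ring on the thiocarbonyl carbon. Compound 4 `N/C(=N\NC(=S)N1CCSCC1)c1ccccn1` differs from compound 2 by thiomorpholin-4-yl in place of morpholin-4-yl on a thiocarbonyl carbon. Going by the values given here, no measured step involves an exchange of thiomorpholin-4-yl for morpholin-4-yl, so nothing in the data points to a direction. The expected step is therefore small, a number 5.3 percentage points higher from compound 2 to compound 4 (within the scatter). Compound 4 is estimated at 18%, with a range from 4% to 40%.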

Compound 4, percent growth inhibition at one concentration: 25.1%
Compound 4: middle estimate off by 7.1 percentage points, on the low side; the range from low to high includes it.
By their numbers in this assay, from the lowest: compound 2; then compound 4; then compound 3; then compound 1.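

In this assay the step of a number 12.4 percentage points higher from compound 2 to compound 4 (beyond the scatter) shows that the ring on a thiocarbonyl carbon also affects the read-out, which the earlier methyl step could not show. Sulfur replaces oxygen here, while the ring size and the counts of donors and acceptors stay the same, so one ring atom is enough to move the number beyond the scatter. Nothing available explains this difference.

Still open, on these data alone, is how piperidin-1-yl, with a plain carbon in that ring position, would compare on the same carbon. Also open, as far as these compounds go, is whether thiomorpholin-4-yl gives a similar step alongside the methyl group of compound 3.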